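This account rests on a few compounds, and the source may have more. Where it says the series, first, only, none or still open, it means among the compounds named here.

Measured compounds:
Compound 1 `Cc1ccccc1Cn1cc(COc2ccc3c(=O)ccoc3c2)nn1` gives a limit in this assay, > 300000 nM.
Compound 2 `CC(C)(C)c1ccc(Cn2cc(COc3ccc4c(=O)ccoc4c3)nn2)cc1` gives a limit in this assay, > 300000 nM.

The readout of interest is an ADME assay on L02 cells (Homo sapiens) for cytotoxicity, read by MTT assay, with a stated time of 48 h; a lower number here means a stronger inhibitor, a higher number a weaker inhibitor. Where compound 1 stands on these numbers cannot be fixed more closely than the assay allows: its value is a limit of the assay and not a number, and the value of compound 2 is a limit as well, so the two show no difference between them. Both values rest at the limit of > 300000 nM in this assay, at which 2 of the 2 values shown sit.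

Compound 3 `O=c1ccoc2cc(OCc3cn(Cc4ccccc4F)nn3)ccc12` has not yet been measured in this assay. It differs from compound 1 in one place: fluoro in place of methyl on an aromatic carbon. Going by the values given here, no measured pair spans a change of this kind, so there is no step in this assay to lean on. Because both values shown sit at the limit of > 300000 nM in this assay, at which 2 of the 2 values shown sit, a step from compound 1 to compound 3 beyond the scatter, in either direction, is not expected; the most likely outcome is that compound 3 again reaches only the assay limit. The step expected from compound 1 to compound 3 is a step that the limit leaves unreadable from compound 1 to compound 3. For compound 3 the estimate in this assay is 400000 nM, with a range from 150000 nM to 1500000 nM.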

Compound 3, half-maximal inhibitory concentration: > 300000 nM
Compound 3: no number, only a limit; the forecaster's own chance of this, stated with the estimate: 85%; the middle value lies beyond the limit too.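

Compound 3, like compound 1, gives only a limit and not a number in this assay, so no step between the two can be read, and all three compounds share the same limit: the limit of > 300000 nM in this assay, at which 3 of the 3 values shown sit.

The compounds shown leave open how far the true values lie beyond that limit, and whether any change to the shared core would bring a value into measurable range in this assay.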